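Working notes: from compound 2 to compound 3

The source may hold more compounds than are shown below. What is called first, only, known or untested is meant among the compounds shown, and "the series" means these compounds.

The series rests on compound 1 `C[Se]/C(=N\C(=O)c1ccco1)NC(=O)c1ccco1` and compound 2 `CS/C(=N\C(=O)c1ccco1)NC(=O)c1ccco1`, which share one core and differ only in the group on the carbon with a double bond to nitrogen. In a functional assay on HT-29 cells (Homo sapiens) for cytotoxicity, read by MTT assay, with a stated time of 72 h (a higher number here means that more compound is tolerated, a lower number that less compound is tolerated), compound 1 gives a limit of the assay, > 100000 nM. In this assay compound 2 likewise gives a limit of the assay, > 100000 nM. The step that the two limits leave unreadable from compound 1 to compound 2 thus has no readable size; both values sit at the limit of > 100000 nM in this assay, at which 2 of the 2 values shown sit. Compound 2 therefore stands at the edge of what the measurement reports, with no number of its own.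

Compound 3 `O=C(/N=C(/NC(=O)c1ccco1)[Se]Cc1ccccc1)c1ccco1` is the next member. It differs from compound 2 by a group of 8 heavy atoms (7 carbon, 1 selenium; one six-membered aromatic ring of carbon only) in place of a group of 2 heavy atoms (1 carbon, 1 sulfur; no ring), on a carbon with a double bond to nitrogen. Going by the values given here, the only measured step, a step that the two limits leave unreadable from compound 1 to compound 2, touches the same place but offers neither size nor direction, so the measured data give no ground to expect a step beyond the scatter in either direction in this assay. Compound 3 is therefore expected to give 80000 nM, within 20000 nM to 200000 nM. The estimated step of an at least 1.2-fold lower number from compound 2 to compound 3 (0.09 log units; that floor lies within the scatter) is accordingly expected to stay small.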

Compound 3, concentration lethal to 50% of the cells: 89100 nM
Estimate against measurement, compound 3: 1.1-fold (0.05 log units) below, within the range that was stated.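

In this assay, going by these compounds alone, compound 3 gives 89100 nM as the first value that is a number and not a limit of the assay, so a group at the place on a carbon with a double bond to nitrogen can bring the read-out into the measured range. The steps of an at least 1.1-fold lower number from compound 2 to compound 3 (0.05 log units; that floor lies within the scatter) and an at least 1.1-fold lower number from compound 1 to compound 3 (0.05 log units; that floor lies within the scatter) both start from a limit, so each is known only as a floor within the scatter, and the second of them corresponds to phenyl in place of hydrogen on a saturated chain carbon bound to a selenium atom. The step between the two earlier compounds cannot be read, and both of them stay at a limit of the assay: the limit of > 100000 nM in this assay, at which 2 of the 3 values shown sit.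

From the compounds shown here alone, whether the same phenyl gives a like read-out with a sulfur atom in place of the selenium atom stays open, as does the true size of both steps. Also open, going by these compounds, is how the read-out responds to a different group at this place, such as a longer alkyl chain on the selenium atom, an amine or a carboxylic acid.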